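Thiophene for phenyl on two nucleoside cores, all at the limit

The source may hold more compounds than are shown below. What is called first, only, known or untested is meant among the compounds shown, and "the series" means these compounds.

The study compares four ribosylated compounds. Compound 1 `CNc1ncnc2c1c(-c1ccccc1)cn2[C@@H]1O[C@H](CO)[C@@H](O)[C@H]1O` and compound 2 `CNc1ncnc2c1c(-c1ccsc1)cn2[C@@H]1O[C@H](CO)[C@@H](O)[C@H]1O` share one core and differ only in one place, thiophen-3-yl in place of phenyl on an aromatic carbon. In a functional assay on CEM-DNR-bulk cells (Homo sapiens), read by MTT assay, with a stated time of 72 h (a higher number here means a weaker inhibitor, a lower number a stronger inhibitor), compound 1 gives a limit of > 20000 nM. In this assay compound 2 likewise gives a limit of > 20000 nM. The step that the two limits leave unreadable from compound 1 to compound 2 therefore cannot be sized, because of the limit of > 20000 nM in this assay, at which 3 of the 3 values shown sit.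

Compound 3 `Nc1nc2c(c(-c3ccccc3)cn2[C@@H]2O[C@H](CO)[C@@H](O)[C@H]2O)c(=O)[nH]1` carries a different core; the difference between the two cores is not broken down here. In this assay compound 3 gives a limit of > 20000 nM.

Compound 4 `Nc1nc2c(c(-c3ccsc3)cn2[C@@H]2O[C@H](CO)[C@@H](O)[C@H]2O)c(=O)[nH]1` is not yet measured. It relates to compound 3 by the same change thiophen-3-yl in place of phenyl on an aromatic carbon that turns compound 1 into compound 2. Among the measured compounds shown here, because of the limit of > 20000 nM in this assay, at which 3 of the 3 values shown sit, no step has yet moved any compound off the limit. The step from compound 3 to compound 4 is expected to be a step that the limit leaves unreadable from compound 3 to compound 4, resting on compound 1 with > 20000 nM and compound 2 with > 20000 nM. Compound 4 is thus expected to give about 40000 nM in this assay, within 15000 nM to 150000 nM.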

Compound 4, half-maximal inhibitory concentration: > 20000 nM
Compound 4 gave a limit, no number; the forecaster's own chance of this, stated with the estimate: 88%; the middle value is on the limit's open side.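

In this assay compound 4, like compound 3, returns only a limit, so the step from compound 3 to compound 4 cannot be read, nor can the step from compound 1 to compound 2: the limit of > 20000 nM in this assay, at which 4 of the 4 values shown sit. The compounds shown leave open how strongly any of them inhibits, and whether in this assay thiophen-3-yl and phenyl differ at all.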